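The source may report more compounds than this note shows. Statements on the series, on what has been measured and on what is new or still open speak of the compounds shown alone.

Measured so far:
- compound 1, `CC(C)=CCC[C@]1(C)/C=C/[C@@H](OC(=O)C=C(C)C)[C@](C)(O)/C=C/C(=O)/C(CN(C(C)C)C(C)C)=C\C1`: 750 nM in a functional assay on SW480 cells (Homo sapiens) for antiproliferative activity, read by MTT assay, with a stated time of 48 h; on this read-out lower numbers stand for stronger inhibition and higher numbers for weaker inhibition
- compound 2, `CC(C)=CCC[C@]1(C)/C=C/[C@@H](OC(=O)C=C(C)C)[C@](C)(O)/C=C/C(O)/C(C=O)=C\C1`: 1430 nM in this assay

For the measured compounds named here, compound 1 has the lowest of the two numbers in this assay; the only other value, that of compound 2, sits close by, and the two values lie within the scatter of each other, so nothing can be said about their order. Going by the values given here, no step between two measured compounds that differ in one place is available for this series.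

Compound 3, `CCN(CC)C(=O)/C1=C/C[C@](C)(CCC=C(C)C)/C=C/[C@@H](OC(=O)C=C(C)C)[C@](C)(O)/C=C/C1=O`, has not been measured. It differs from compound 1 as follows: diethylcarbamoyl in place of (diisopropylamino)methyl on a double-bonded ring carbon. The shared core, the ester and the hydroxy group are untouched.

Among the compounds with values here, with no comparable step among the measured compounds, the expectation for compound 3 rests on the two values alone. In this assay the step from compound 1 to compound 3 is expected to be a 1.6-fold higher number from compound 1 to compound 3 (0.20 log units; within the scatter), a modest rise that need not exceed the scatter. Compound 3 is therefore estimated at 1200 nM, with a range from 400 nM to 3600 nM.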

Compound 3, half-maximal inhibitory concentration: 11700 nM
Compound 3: the middle estimate sits 9.8-fold (0.99 log units) below what was measured; the whole stated range lies below it.
By their numbers in this assay, from the lowest: compounds 1 and 2 (each within the scatter of the next); then compound 3.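

In this assay, diethylcarbamoyl in place of (diisopropylamino)methyl on the double-bonded ring carbon gives a 16-fold higher number from compound 1 to compound 3 (1.19 log units; beyond the scatter), so the read-out depends on what this ring carbon carries; compound 1 and compound 2 differ in more than one place and could not show this. The shared core, the ester and the hydroxy group are the same in compound 1 and compound 3, which places the whole step on this single exchange. No measurement here bears on the reason for the step.

The exchange changes the carbonyl and the alkyl groups on nitrogen together, and a (diethylamino)methyl group on this carbon would separate the two. As far as these compounds go, how a cyclic amine such as pyrrolidin-1-ylmethyl or a carboxylic acid would read at this position also stays open.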